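The source may report more compounds than this note shows. Statements on the series, on what has been measured and on what is new or still open speak of the compounds shown alone.

Measured compounds:
- compound 1, `O=C(CCCCC1CCSS1)NCc1cn(CCCOc2ccc3cc(-c4ccc(Cl)c(Cl)c4)c(=O)oc3c2)nn1`: 54.8%
- compound 2, `O=C(CCCCC1CCSS1)NCc1cn(CCCCOc2ccc3ccc(=O)oc3c2)nn1`: 75.8%

Of the compounds shown here, two have been measured in a functional assay on PC-12 cells (Rattus norvegicus) for cytotoxicity, read by MTT assay, with stated times of 3 h and 2 h, tested at 50 uM; on this read-out higher numbers stand for a stronger effect at the one concentration tested and lower numbers for a weaker effect. Compound 2 gives the higher of the two numbers, and compound 1 sits a clear distance lower, a gap that goes beyond the usual scatter of such measurements. Among the measured compounds shown here, the two compounds differ in more than one place, so the gap between them cannot be tied to a single change; it shows only that compound 1 produced less of an effect than compound 2 at the concentration tested.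

The next compound, compound 3, `COc1ccc(-c2cc3ccc(OCCCCn4cc(CNC(=O)CCCCC5CCSS5)nn4)cc3oc2=O)cc1`, differs from compound 2 in a single place: 4-methoxyphenyl in place of hydrogen on an aromatic carbon. For the measured compounds named here, no step between measured compounds tells how this exact change plays out. Going by the values given here, the only hint comes from compound 1, which also carries an aromatic ring at that position and gave 54.8%, below compound 2. On that slender basis, a downward step of moderate size is expected for compound 3, as a number 13.8 percentage points lower from compound 2 to compound 3 (beyond the scatter), with a wide range allowed. Compound 3 is therefore estimated to give 62%, between 45% and 80%.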

Compound 3, a percentage reported as activity, at one concentration (the size of the read-out at that concentration, not a potency): 55.3%
Compound 3: middle estimate off by 6.7 percentage points, on the high side; measured number inside the range.
By their numbers in this assay, from the lowest: compounds 1 and 3 (each within the scatter of the next); then compound 2.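

Placing 4-methoxyphenyl on the aromatic carbon two atoms from the ring oxygen gives, in this assay, a number 20.5 percentage points lower from compound 2 to compound 3 (beyond the scatter), a drop beyond the usual scatter of this measurement. Unlike the gap between compound 1 and compound 2, which involves more than one structural difference, this drop can be tied to a single change at one position on the shared core. The added group lowers the read-out without removing it, since compound 3 still gives 55.3% at the one concentration tested, but nothing measured here explains why this single change has that effect.

The step cannot separate the contribution of the aromatic ring from that of the methoxy group on it, so a plain phenyl group at the same carbon would be the most direct comparison. From the compounds shown here alone, how far the result extends to other kinds of group at this position also remains open, for instance a small methyl group, an amine or a carboxylic acid.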